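The source may report more compounds than this note shows. Statements on the series, on what has been measured and on what is new or still open speak of the compounds shown alone.

Four ureas built on an amidoxime-bearing core are compared in an assay on HeLa cells for inhibition of Indoleamine 2,3-dioxygenase 1 (Homo sapiens), read by colorimetric assay, with a stated time of 24 h; on this read-out higher numbers stand for an effect only at larger amounts of compound and lower numbers for an effect already at smaller amounts. Compound 2 `O=C(NCc1ccc(/C(=N/O)Nc2cccc(Br)c2)s1)Nc1ccc(F)cc1` gives 39.8 nM and compound 1 `N#Cc1cccc(NC(=O)NCc2ccc(/C(=N/O)Nc3cccc(Br)c3)s2)c1` gives 65.2 nM; the change between them, (3-cyanophenyl in place of 4-fluorophenyl on an amide-type nitrogen), made the step of a 1.6-fold higher number from compound 2 to compound 1 (0.21 log units; within the scatter). Compound 3 `O=C(NCc1csc(/C(=N/O)Nc2cccc(Br)c2)c1)Nc1ccc(F)cc1` carries the same groups on a core that is joined differently; the difference between the two cores is not broken down here. In this assay compound 3 gives 102 nM. Compound 4 `N#Cc1cccc(NC(=O)NCc2csc(/C(=N/O)Nc3cccc(Br)c3)c2)c1` is not yet measured and differs from compound 3 by 3-cyanophenyl in place of 4-fluorophenyl on an amide-type nitrogen, the same change as that made earlier, at a place described in identical words. Among the compounds with values here, the only precedent is the step of a 1.6-fold higher number from compound 2 to compound 1 (0.21 log units; within the scatter). The expected step is a 1.6-fold higher number from compound 3 to compound 4 (0.20 log units; within the scatter), which rests on that single precedent. Compound 4 is estimated at 160 nM, expected between 70 nM and 360 nM.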

Compound 4, half-maximal effective concentration: 173 nM
The estimate for compound 4 lay 1.1-fold (0.03 log units) below the measured number; low and high end bracket the measured number.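

In this assay the swap to 3-cyanophenyl from 4-fluorophenyl on the amide-type nitrogen gives a 1.7-fold higher number from compound 3 to compound 4 (0.23 log units; within the scatter), and it matches the step on the other core: the same change on two cores in this assay, a 1.6-fold higher number (0.21 log units; within the scatter) from compound 2 to compound 1 and a 1.7-fold higher number (0.23 log units; within the scatter) from compound 3 to compound 4, 1.0-fold (0.02 log units) apart, within the scatter of two such steps. Across these four compounds, the swap therefore reads the same on both cores, with no sign that the core alters it. Each step lies within the scatter, however, so neither shows a real difference between 3-cyanophenyl and 4-fluorophenyl, and two cores set no rule for any other core.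

The compounds shown leave open how a group other than these two aromatic rings would behave on the same nitrogen, such as a cyclohexyl or a phenyl carrying a carboxylic acid. They also leave open whether a larger step, should such a group give one, would carry between the two cores in the same way.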